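Swapping a Benzyl Sulfide Arm for Isopropyl

The source may report more compounds than this note shows. Statements on the series, on what has been measured and on what is new or still open speak of the compounds shown alone.

Compound 1 `CCSc1n[nH]c(-n2[se]c3ccccc3c2=O)n1`: 35200 nM
Compound 2 `Cc1cccc(CSc2n[nH]c(-n3[se]c4ccccc4c3=O)n2)c1`: > 50000 nM
Compound 3 `O=c1c2ccccc2[se]n1-c1nc(SCc2ccc(Cl)cc2)n[nH]1`: 39500 nM

In an ADME assay on L929 cells (Mus musculus) for antiproliferative activity, read by CCK-8 assay, with a stated time of 48 h (on this read-out lower numbers stand for stronger inhibition and higher numbers for weaker inhibition), compound 3 gives 39500 nM, the higher of the two numbers shown; compound 1 sits close by, with a 1.1-fold higher number from compound 1 to compound 3 (0.05 log units; within the scatter). Compound 2 reached only a limit of the assay, (the limit of > 50000 nM in this assay, at which 1 of the 3 values shown sits). Compound 4 `CC(C)Sc1n[nH]c(-n2[se]c3ccccc3c2=O)n1` is not yet measured; it differs from compound 3 in that (isopropyl in place of 4-chlorobenzyl on a sulfur). Among the compounds with values here, the step that bears most on this is the one from a methyl group to a 4-chlorobenzyl group, a 1.1-fold higher number from compound 1 to compound 3 (0.05 log units; within the scatter), which stayed within the scatter; an at least 1.2-fold lower number from compound 2 to compound 3 (0.10 log units; that floor lies within the scatter) also adds little. Accordingly compound 4 is expected to show no change beyond the scatter, a 1.2-fold lower number from compound 3 to compound 4 (0.07 log units; within the scatter). The estimate for compound 4 is 34000 nM, with a range from 15000 nM to 75000 nM.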

Compound 4, half-maximal inhibitory concentration: 37100 nM
Compound 4: middle estimate off by 1.1-fold (0.04 log units), on the low side; measured number inside the range.
By their numbers in this assay, from the lowest: compounds 1, 4 and 3 (each within the scatter of the next). At a limit, above all of these: compound 2.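

In this assay, isopropyl in place of 4-chlorobenzyl on the sulfur gives a 1.1-fold lower number from compound 3 to compound 4 (0.03 log units; within the scatter), so this position tolerates losing the aromatic ring without a change beyond the scatter. Adding a methyl to the small chain gives a 1.1-fold higher number from compound 1 to compound 4 (0.02 log units; within the scatter), which is also no real change. The step from the other benzyl compound, an at least 1.3-fold lower number from compound 2 to compound 4 (0.12 log units; that floor lies within the scatter), is only a floor, as the value of compound 2 is a limit: the limit of > 50000 nM in this assay, at which 1 of the 4 values shown sits.

On these data alone, whether an amine or a carboxylic acid on this chain would shift the number beyond the scatter remains open.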